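Varying the Amino Substituent: Notes Toward Compound 4

A few compounds are considered here, and "the series" means these few. Any claim that something is new, unique, unknown or untested is made for them only; others in the source may bear on it.

Measured so far in a functional assay on CHO-K1 cells for antagonist activity at transient receptor potential cation channel subfamily V member 1 (Homo sapiens), read by FLIPR; on this read-out lower numbers stand for stronger inhibition and higher numbers for weaker inhibition:
compound 1, `CCCN(CCC)c1nc(C(F)(F)F)ccc1CNC(=O)C(C)c1ccc(NS(C)(=O)=O)c(F)c1`, gives 0.2 nM
compound 2, `CCCCN(C)c1nc(C(F)(F)F)ccc1CNC(=O)C(C)c1ccc(NS(C)(=O)=O)c(F)c1`, gives 0.8 nM
compound 3, `CC(C(=O)NCc1ccc(C(F)(F)F)nc1N1CCC(C)(C)CC1)c1ccc(NS(C)(=O)=O)c(F)c1`, gives 0.3 nM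

Compound 3 holds the second highest of the three numbers in this assay. Its nearest neighbour is compound 1: the step of a 1.5-fold higher number from compound 1 to compound 3 (0.18 log units; within the scatter) lies within the scatter, so the two cannot be ordered. Its furthest neighbour is compound 2, with a 2.7-fold lower number from compound 2 to compound 3 (0.43 log units; beyond the scatter), a modest step beyond the scatter.

Compound 4, `CC(C(=O)NCc1ccc(C(F)(F)F)nc1N1CCC(c2ccccc2)CC1)c1ccc(NS(C)(=O)=O)c(F)c1`, differs from compound 3 only at the amino substituent: 4-phenylpiperidin-1-yl in place of 4,4-dimethylpiperidin-1-yl on an aromatic carbon. Among the compounds with values here, no measured pair tests a phenyl-bearing ring at this position, so the bearing steps are only those that exchange one amino substituent for another on the shared core: a 4.0-fold higher number from compound 1 to compound 2 (0.60 log units; beyond the scatter), a 1.5-fold higher number from compound 1 to compound 3 (0.18 log units; within the scatter) and a 2.7-fold lower number from compound 2 to compound 3 (0.43 log units; beyond the scatter). All three stay modest. A modest step in this assay is therefore expected for compound 4, most likely toward a higher number, expressed as a 2.0-fold higher number from compound 3 to compound 4 (0.30 log units; within the scatter). For compound 4 the estimate is 0.6 nM, with a range from 0.15 nM to 2.5 nM.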

Compound 4, inhibition constant: 0.6 nM
Compound 4: middle estimate and measured number agree at the digits printed, within the range that was stated.
By their numbers in this assay, from the lowest: compounds 1, 3, 4 and 2 (each within the scatter of the next, the first and the last beyond it).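

A phenyl-bearing ring is accepted at this position in this assay: with 4-phenylpiperidin-1-yl in place of the earlier amino substituents, a 2.0-fold higher number from compound 3 to compound 4 (0.30 log units; within the scatter) and a 1.3-fold lower number from compound 2 to compound 4 (0.12 log units; within the scatter) leave compound 4 unordered against both compound 3 and compound 2. Only the comparison with the dipropylamino group separates the values, with a 3.0-fold higher number from compound 1 to compound 4 (0.48 log units; beyond the scatter), so adding an aromatic ring to the piperidine produces a modest step at most among the pairs shown. No evidence is available on why this substituent is accepted here.

The compounds shown leave open how a 4-benzylpiperidin-1-yl or morpholin-4-yl group would read on the shared core. They also leave open whether a carboxylic acid or an amine on the phenyl ring would be accepted.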